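Isopropyl for Methyl on an Ethyl Ester Furan Core

A few compounds are considered here, and "the series" means these few. Any claim that something is new, unique, unknown or untested is made for them only; others in the source may bear on it.

Measured compounds:
compound 1, `CC(C)c1oc2nc(N3CCCC3)ccc2c1C(=O)O`: "not determined" (no result reported)
compound 2, `CCOC(=O)c1c(C)oc2nc(N3CCCC3)ccc12`: > 364000 nM

Compound 1, `CC(C)c1oc2nc(N3CCCC3)ccc2c1C(=O)O`, has no result in an ADME assay on MRC5 cells (Homo sapiens) for cytotoxicity, read by fluorescence and resazurin assay, with a stated time of 24 h; a higher number here means a weaker inhibitor, a lower number a stronger inhibitor. In this assay compound 2, `CCOC(=O)c1c(C)oc2nc(N3CCCC3)ccc12`, reaches only a limit of the assay, > 364000 nM, so no single number places it. Of the two entries shown, one is a limit and one carries no number at all, a situation summed up by the limit of > 364000 nM in this assay, at which 1 of the 2 values shown sits.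

Compound 3, `CCOC(=O)c1c(C(C)C)oc2nc(N3CCCC3)ccc12`, differs from compound 2 in one place: isopropyl in place of methyl on an aromatic carbon.

Within the data shown here, no step between measured compounds exists here, so the size of this change can only be judged from the limit compound 2 shows. From compound 2 to compound 3 a step expected in this assay is an at least 1.2-fold lower number from compound 2 to compound 3 (0.08 log units; that floor lies within the scatter), which is none beyond the scatter. Compound 3 is therefore estimated at 300000 nM, with a range from 100000 nM to 1000000 nM, and most likely only a limit would again be reported.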

Compound 3, half-maximal inhibitory concentration: > 330000 nM
Compound 3: a limit, no number; the forecaster's own chance of this, stated with the estimate: 75%; middle value at least 1.1-fold (0.04 log units) from the limit.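

In this assay compound 3 gives > 330000 nM, which is a limit of the assay. Compound 2 also stands at a limit, so no step can be read between compound 2 and compound 3. The compounds shown leave open whether isopropyl in place of methyl on an aromatic carbon changes the cytotoxicity at all.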